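Ether-linked cationic heterocycles on the dioxolane core

The compounds below may be only part of what the source reports. "The series", "measured", "known", "first", "only" and "open" are said of these compounds alone.

Measured so far:
compound 1, `CCCCCCCCCCCCCCCCCC1OCC(COCCCCCC[n+]2ccccc2)O1` — 3000 nM
compound 2, `CCCCCCCCCCCCCCCCCC1OCC(COC(=O)CCCCC[n+]2ccsc2)O1` — 1100 nM
compound 3, `CCCCCCCCCCCCCCCCCC1OCC(COCCCCCCCC[n+]2ccsc2)O1` — 3700 nM

All three were run in a functional assay (Oryctolagus cuniculus) for inhibition of platelet-activating factor receptor (Cavia porcellus); a lower number here means a stronger inhibitor, a higher number a weaker inhibitor. Compound 3 gives the highest number of the three. Its nearest neighbour is compound 1: the step of a 1.2-fold higher number from compound 1 to compound 3 (0.09 log units; within the scatter) stays within the scatter, so the two read as equivalent. Among the compounds with values here, the ester-linked compound 2 sits further off, with a 2.7-fold lower number from compound 1 to compound 2 (0.44 log units; beyond the scatter) as the one step beyond the scatter in this small set.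

Compound 4, `CCCCCCCCCCCCCCCCCC1OCC(COCCCCCC[n+]2cscc2C)O1`, is unmeasured. It differs from compound 3 by a group of 6 heavy atoms (4 carbon, 1 nitrogen, 1 sulfur; one five-membered aromatic ring with 2 hetero atoms) in place of a group of 7 heavy atoms (5 carbon, 1 nitrogen, 1 sulfur; one five-membered aromatic ring with 2 hetero atoms), on a saturated chain carbon, six bonds along the chain from an oxygen on a saturated carbon. Within the data shown here, the step that bears on it is the one from compound 1 to compound 3, where swapping the cationic ring and lengthening the chain left the number essentially unchanged. Nothing here tests the added methyl on the ring, and the change in chain length between compound 3 and compound 4 has only compound 1 as a point of comparison. On that basis the step of a 1.2-fold lower number from compound 3 to compound 4 (0.09 log units; within the scatter) is expected to be small, with no direction that stands out beyond the scatter. Compound 4 is therefore estimated at 3000 nM, in the range 1200 nM to 7500 nM.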

Compound 4, half-maximal inhibitory concentration: 3100 nM
Beside the measured number, compound 4's estimate is 1.0-fold (0.01 log units) below it, and the stated range covers the measured number.
By their numbers in this assay, from the lowest: compound 2; then compounds 1, 4 and 3 (each within the scatter of the next).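

In this assay the step of a 1.2-fold lower number from compound 3 to compound 4 (0.08 log units; within the scatter) stays within the scatter, so at this place, on a saturated chain carbon, six bonds along the chain from an oxygen on a saturated carbon, the group of 6 heavy atoms and the group of 7 heavy atoms read as equivalent. Within the data shown here, the step of a 1.0-fold higher number from compound 1 to compound 4 (0.01 log units; within the scatter) is also within the scatter, and it gives the first comparison at this place of a five-membered aromatic ring with 2 hetero atoms and a six-membered aromatic ring with 1 hetero atom in groups that differ in no other count of chain length, so the change of ring alone leaves the number flat. The step of a 2.8-fold higher number from compound 2 to compound 4 (0.45 log units; beyond the scatter) lies beyond the scatter but stays modest, and it leaves compound 2, the one carbonyl-containing linker here, apart from all three ether-linked compounds on the strength of a single example.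

On these data alone, whether an amide in that linker would give a number like that of compound 2 remains open. Also open, as far as these compounds go, is whether a trimethylammonium group in place of the aromatic ring would depart from the flat reading seen so far. No measured evidence available here bears on the reason for any of these steps.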